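This account rests on a few compounds, and the source may have more. Where it says the series, first, only, none or still open, it means among the compounds named here.

Measured compounds:
- compound 1 `CCCCCCCC(=O)O[C@]12C=CC(=O)C[C@H]1OCC2` gives 0.8 ug/mL
- compound 2 `O=C1C=C[C@]2(OC(=O)c3ccccc3)CCO[C@@H]2C1` gives 1.6 ug/mL
- compound 3 `OC1C=C[C@]2(O)CCO[C@@H]2C1` gives > 100 ug/mL

In a functional assay on HeLa S3 cells (Homo sapiens) for cytotoxicity (a lower number here means a stronger inhibitor, a higher number a weaker inhibitor), compound 1 and compound 2 both return numbers. Compound 3 does not: for compound 3 the result is a limit of the assay, not a measured value. Compound 3 therefore sits at the limit of > 100 ug/mL in this assay, at which 1 of the 3 values shown sits, the weakest position any of the three occupies.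

Compound 4 `CC(=O)O[C@]12C=CC(O)C[C@H]1OCC2` is not yet measured in this assay. It differs from compound 3 in one place (acetyl in place of hydrogen on an oxygen on a saturated carbon). Compound 1 and compound 2 both carry an ester on the same oxygen of the shared core and both give numbers, but each also carries a conjugated carbonyl that compound 3 and compound 4 lack, so the two comparisons do not separate the two changes.

He expects the step from compound 3 to compound 4 to be modest, at best a gain that just clears the scatter, and the step is estimated at an at least 2.0-fold lower number from compound 3 to compound 4 (0.30 log units; that floor lies within the scatter). For compound 4 in this assay he estimates 50 ug/mL, in a range from 10 ug/mL to 200 ug/mL.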

Compound 4, half-maximal inhibitory concentration: > 100 ug/mL
Compound 4 was reported as a limit; the forecaster's own chance of this, stated with the estimate: 45%; middle value at least 2.0-fold (0.30 log units) from the limit.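

In this assay compound 4 gives > 100 ug/mL, a limit of the assay and not a number. Compound 3 also stands at a limit, so no step can be read between compound 3 and compound 4: the limit of > 100 ug/mL in this assay, at which 2 of the 4 values shown sit. The compounds shown leave open whether acetyl in place of hydrogen on an oxygen on a saturated carbon changes the read-out in this assay at all, and by how much.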